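A few compounds are considered here, and "the series" means these few. Any claim that something is new, unique, unknown or untested is made for them only; others in the source may bear on it.

Series notes, amide variation on the shared core. For the measured compounds named here, compound 3 `COc1cccc(N(C)c2ccc(NC(=O)C(C)C)cc2)c1` stands highest on the numbers so far: in an assay on isolated protein for binding affinity to melatonin receptor type 1A (Homo sapiens) (on this read-out lower numbers stand for stronger inhibition and higher numbers for weaker inhibition), compound 3 gives 106 nM. Compound 1 `COc1cccc(Nc2ccc(NC(=O)C3CC3)cc2)c1` gives 61 nM, a gap to compound 3 that is within the scatter, and the two differ at two places, so nothing is read from that pair alone. Going by the values given here, compound 2 `CCC(=O)Nc1ccc(N(C)c2cccc(OC)c2)cc1` gives 1 nM, and the single step of a 110-fold higher number from compound 2 to compound 3 (2.03 log units; beyond the scatter) is the only one that touches the carbonyl substituent.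

Compound 4 `COc1cccc(N(C)c2ccc(NC(=O)C3CC3)cc2)c1` takes the step (cyclopropyl in place of isopropyl on a carbonyl carbon). Among the compounds with values here, the step from compound 2 to compound 3 shows how costly a methyl on the chain carbon bound to the carbonyl carbon was; the cyclopropyl entering in compound 4 is a ring of the same heavy-atom count rather than a branched chain, and no measured step shows whether the ring is tolerated differently. Compound 1 carries the same cyclopropylcarbonyl group and sits within the scatter of compound 3, which argues for only a modest move. For compound 4 in this assay the expected step is a 3.0-fold lower number from compound 3 to compound 4 (0.48 log units; beyond the scatter), a moderate improvement at most. The estimate for compound 4 is 35 nM, with a range from 6 nM to 150 nM.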

Compound 4, inhibition constant: 12 nM
Estimate against measurement, compound 4: 2.9-fold (0.46 log units) above, within the range that was stated.
By their numbers in this assay, from the lowest: compound 2; then compound 4; then compounds 1 and 3 (each within the scatter of the next).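

In this assay, with the heavy-atom count on the carbonyl carbon unchanged, the ring gives a clear gain over the branched chain (an 8.8-fold lower number from compound 3 to compound 4 (0.95 log units; beyond the scatter)), so the loss seen with isopropyl does not follow from that count alone in this pair. Cyclopropyl still does not match ethyl (a 12-fold higher number from compound 2 to compound 4 (1.08 log units; beyond the scatter)), which gives the order ethyl, cyclopropyl, isopropyl at this place for the three compounds with the methylated nitrogen, each step beyond the scatter. For the compounds shown here, compound 4 also gives the first single-place reading of the nitrogen on the aromatic ring: with the cyclopropylcarbonyl group held fixed, methyl in place of hydrogen there gives a 5.1-fold lower number from compound 1 to compound 4 (0.71 log units; beyond the scatter).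

No measured evidence accounts for the difference between the ring and the branched chain. Still open, going by these compounds, is whether a cyclobutyl group or a longer chain such as propyl on the carbonyl carbon would stand nearer to ethyl or to isopropyl, and whether methyl on the nitrogen brings a step of similar size when ethyl or isopropyl sits on the carbonyl carbon.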